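The compounds below may be only part of what the source reports. "The series", "measured", "known", "first", "only" and "open" are said of these compounds alone.

Working notes on the series, following the move from compound 1 to compound 3.

Compound 1, `Fc1cnc(NCc2ccc(CNc3nccc(C(F)(F)F)n3)cc2)nc1`, was tested in a functional assay on MDA-MB-231 cells for antagonist activity at C-X-C chemokine receptor type 4 (Homo sapiens), tested at 10 nM (a lower number here means a weaker effect, a higher number a stronger effect of the compound at the concentration tested), and gives 73%. Only one other member of the series has a number in this assay: compound 2, `COc1ncc(F)c(NCc2ccc(CNc3nc(OC)ncc3F)cc2)n1`, gives 77%, and the gap between the two lies within the usual scatter of this kind of measurement, so on the numbers shown compound 1 stands alongside compound 2 rather than apart from it. Among the compounds with values here, no pair of compounds differing in a single place has been measured, so no step between measured compounds can be quoted.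

Compound 3, `CSc1ccnc(NCc2ccc(CNc3ncc(F)cn3)cc2)n1`, has not yet been measured in this assay. It differs from compound 1 in one place: methylsulfanyl in place of trifluoromethyl on an aromatic carbon. Within the data shown here, the series offers no measured step that touches this position, so the expectation rests on the two numbers above alone. The step of a number 8 percentage points lower from compound 1 to compound 3 (within the scatter) is expected to be small, if anything downward, and not clearly beyond the scatter. For compound 3 in this assay the estimate is 65%, with a range from 40% to 85%.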

Compound 3, a percentage reported as inhibition, at one concentration (the size of the read-out at that concentration, not a potency): 62%
For compound 3 the middle estimate is 3 percentage points above the measured one; the measured number falls inside the stated range.
By their numbers in this assay, from the lowest: compound 3; then compounds 1 and 2 (each within the scatter of the next).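

Within the data shown here, this is the first step that can be read at a single place. In this assay, methylsulfanyl in place of trifluoromethyl, on an aromatic carbon next to the ring nitrogen, gives a number 11 percentage points lower from compound 1 to compound 3 (beyond the scatter). The position is therefore not indifferent to the group it carries, although the step is modest, and it describes the read-out at one concentration rather than a change in potency. No measurement bearing on the reason for this step is available.

A single exchange cannot separate what leaving trifluoromethyl contributes from what entering methylsulfanyl contributes, so the step marks one pair of groups and sets no trend for this position. As far as these compounds go, it remains open how an amine, a nitrile or a longer chain such as ethylsulfanyl at the same aromatic carbon would compare on the core of compound 1, and whether any of them would stay level with trifluoromethyl or fall further than methylsulfanyl.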